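Aryl ketone variation on a shared core: cytotoxicity notes

The compounds below may be only part of what the source reports. "The series", "measured", "known", "first", "only" and "open" are said of these compounds alone.

In an ADME assay on Vero cells (Chlorocebus sabaeus) for cytotoxicity, read by MTT assay, with a stated time of 72 h (on this read-out higher numbers stand for lower toxicity in this test and lower numbers for higher toxicity in this test), compound 1 `COC(=O)/C=C1/Oc2ccccc2NC1=O` shows "not determined" (no result reported). Among the compounds with values here, compound 2 `O=C1Oc2ccccc2N/C1=C\C(=O)c1ccccc1Cl` holds the only number in the set: in this assay compound 2 gives 1570000 nM, so it stands alone with nothing to rank it against. Compound 3 `Cc1cccc(C(=O)/C=C2\Nc3ccccc3OC2=O)c1` differs from compound 2 by 3-methylphenyl in place of 2-chlorophenyl on a carbonyl carbon. Within the data shown here, no step between measured compounds exists to calibrate this change. The change is expected to move the read-out in this assay by no more than the usual scatter, and the step of a 1.0-fold lower number from compound 2 to compound 3 (0.02 log units; within the scatter) is estimated accordingly. Compound 3 is therefore expected to give about 1500000 nM in this assay, within a range from 600000 nM to 3500000 nM.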

Compound 3, half-maximal cytotoxic concentration: > 1790000 nM
Compound 3 was reported as a limit (the forecaster's own chance of this, stated with the estimate: 25%); middle value at least 1.1-fold (0.07 log units) from the limit.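

In this assay, within the data shown here, 3-methylphenyl in place of 2-chlorophenyl on a carbonyl carbon gives an at least 1.1-fold higher number from compound 2 to compound 3 (0.05 log units; that floor lies within the scatter), the first step at this position. Compound 3 is recorded as a limit, > 1790000 nM, not as a number. This step therefore sets only a floor, and the true size of the change remains unknown: the limit of > 1790000 nM in this assay, at which 1 of the 3 values shown sits.

From the compounds shown here alone, it remains open how an amine, a carboxylic acid or a longer chain on this carbonyl carbon would read in this assay. Going by these compounds, whether compound 2 and compound 3 truly differ also remains open.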